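Moving a methoxy group on the amide nitrogen substituent

This account rests on a few compounds, and the source may have more. Where it says the series, first, only, none or still open, it means among the compounds named here.

Measured so far:
compound 1 `COc1ccc2c(=O)c(/C=C/C(=O)Nc3ccc(C)cc3)coc2c1` — 39300 nM
compound 2 `COc1ccc2c(=O)c(/C=C/C(=O)NCc3ccccc3F)coc2c1` — 34000 nM
compound 3 `COc1ccc2c(=O)c(/C=C/C(=O)Nc3ccccc3OC)coc2c1` — 17600 nM

Three compounds share the same core and differ only in the group on the amide-type nitrogen. In a functional assay (QGY7701 cells, Homo sapiens) for inhibition, read by MTT assay, with a stated time of 48 h (a higher number here means a weaker inhibitor, a lower number a stronger inhibitor), compound 3 gives the lowest of the three numbers. Its nearest neighbour is compound 2, with a 1.9-fold lower number from compound 2 to compound 3 (0.29 log units; within the scatter); the widest gap is a 2.2-fold lower number from compound 1 to compound 3 (0.35 log units; beyond the scatter). The remaining pair shows a 1.2-fold lower number from compound 1 to compound 2 (0.06 log units; within the scatter).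

Compound 4 `COc1ccc(NC(=O)/C=C/c2coc3cc(OC)ccc3c2=O)cc1` is unmeasured. It differs from compound 3 only in this: 4-methoxyphenyl in place of 2-methoxyphenyl on an amide-type nitrogen

Among the measured compounds shown here, no measured step moves a methoxy group from one position to another; the steps that bear on the change only loosely are a 2.2-fold lower number from compound 1 to compound 3 (0.35 log units; beyond the scatter), which exchanged a 4-methylphenyl for a 2-methoxyphenyl, and a 1.9-fold lower number from compound 2 to compound 3 (0.29 log units; within the scatter). All three measured values sit in a narrow band, so a step of no more than the usual scatter is expected in this assay, with no firm direction. Compound 4 is therefore estimated at 22000 nM, with a range from 8000 nM to 60000 nM, which would mean an expected step of a 1.3-fold higher number from compound 3 to compound 4 (0.10 log units; within the scatter).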

Compound 4, half-maximal inhibitory concentration: > 100000 nM
Compound 4 gave a limit, no number; the forecaster's own chance of this, stated with the estimate: 5%; middle value at least 4.5-fold (0.65 log units) from the limit.
By their numbers in this assay, from the lowest: compounds 3, 2 and 1 (each within the scatter of the next, the first and the last beyond it). At a limit, above all of these: compound 4.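

In this assay compound 4 gives > 100000 nM, which is a limit of the assay and not a number. Among the compounds shown here, with the same atoms joined differently, 4-methoxyphenyl in place of 2-methoxyphenyl on the amide-type nitrogen gives an at least 5.6-fold higher number from compound 3 to compound 4 (0.75 log units; beyond the scatter), so this substituent responds to where the methoxy sits and not only to which group is present, something the earlier compounds could not show. The other steps run the same way, with an at least 2.9-fold higher number from compound 2 to compound 4 (0.46 log units; beyond the scatter) and an at least 2.5-fold higher number from compound 1 to compound 4 (0.40 log units; beyond the scatter), the last being methoxy in place of methyl on an aromatic carbon, so compound 4 falls outside the narrow band held by the other three compounds.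

From the compounds shown here alone, how far compound 4 lies past its limit stays open, and with it the true size of all three steps. Also open, going by these compounds, is whether a hydroxy group, an amine or a carboxylic acid in place of the methoxy on this phenyl ring would follow compound 3 or compound 4.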